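Ester variants in the shared series: whole-organism inhibition

The source may hold more compounds than are shown below. What is called first, only, known or untested is meant among the compounds shown, and "the series" means these compounds.

Compound 1 `CCCc1nc(C(C)(C)O)c(C(=O)O)n1Cc1ccc(-c2ccccc2C(=O)O)cc1` is the parent acid of the set; in a functional assay on the whole organism for inhibition, with Rattus norvegicus as the target, with a stated time of 1 h, at a dose of 1 mg/kg (a higher number here means more inhibition at the dose given (going by the name of the read-out), a lower number less inhibition), compound 1 gives 50%. Compound 2 `CCCc1nc(C(C)(C)O)c(C(=O)OCc2coc(=O)o2)n1Cc1ccc(-c2ccccc2C(=O)O)cc1` gives 72% in this assay, and compound 3 `CCCc1nc(C(C)(C)O)c(C(=O)OCOC(=O)C(C)(C)C)n1Cc1ccc(-c2ccccc2C(=O)O)cc1` gives 52% in this assay. Compound 3 thus stands second of the three numbers: against compound 1 the step is a number 2 percentage points higher from compound 1 to compound 3 (within the scatter), while from compound 2 the step is a number 20 percentage points lower from compound 2 to compound 3 (beyond the scatter), so only the ring-bearing ester of compound 2 separates itself from the other two.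

Compound 4 `CCCc1nc(C(C)(C)O)c(C(=O)OCOC(=O)OC(C)C)n1Cc1ccc(-c2ccccc2C(=O)O)cc1` is the next member. The change from compound 3 is isopropoxy in place of tert-butyl on a carbonyl carbon. For the measured compounds named here, two measured steps bear on it: a number 2 percentage points higher from compound 1 to compound 3 (within the scatter) shows that attaching the (((tert-butyl)carbonyl)oxy)methyl group does not move the read-out, and a number 20 percentage points lower from compound 2 to compound 3 (beyond the scatter) shows that an ester bearing an additional oxygen within a small ring reads higher. The present change also brings one more oxygen into the ester, but without a ring, so the comparison points to a number level with that of compound 3 rather than a higher one. In this assay compound 4 is expected to give 57%, with a range from 40% to 76%. The expected step is a number 5 percentage points higher from compound 3 to compound 4 (within the scatter), within the scatter.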

Compound 4, a percentage reported as inhibition, in the whole organism at one dose (the size of the read-out at that dose, not a potency): 71%
Estimate against measurement, compound 4: 14 percentage points below; the range from low to high includes it.
By their numbers in this assay, from the lowest: compounds 1 and 3 (each within the scatter of the next); then compounds 4 and 2 (each within the scatter of the next).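

In this assay the group on the carbonyl carbon proves to matter: isopropoxy in place of tert-butyl is a step beyond the scatter (a number 19 percentage points higher from compound 3 to compound 4 (beyond the scatter)), and the ((isopropoxycarbonyl)oxy)methyl ester separates from the parent acid (a number 21 percentage points higher from compound 1 to compound 4 (beyond the scatter)), which the (((tert-butyl)carbonyl)oxy)methyl ester did not do. A ring in the ester is not needed for this reading, as the open-chain ester of compound 4 cannot be told apart from the ring-bearing ester of compound 2 (a number 1 percentage points lower from compound 2 to compound 4 (within the scatter)), leaving two pairs, compounds 1 and 3 and compounds 2 and 4. Nothing at hand accounts for the effect of exchanging tert-butyl for isopropoxy.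

Open, from the compounds shown here alone, is whether the gain follows the oxygen joined to this carbonyl carbon or the isopropyl group it carries, which a methoxy, a cyclohexyloxy or an isopropyl group on the same carbon would help to separate. The readings also come from one dose at one time, so they give no potency order for the esters.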